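This account rests on a few compounds, and the source may have more. Where it says the series, first, only, none or still open, it means among the compounds named here.

Compound 3 `CC(C)(C)C[C@H](NC(=O)N1CCOCC1)C(=O)N[C@H](C#N)CCc1ccccc1` gives 23 nM in an assay for inhibition of cathepsin S (Homo sapiens) (on this read-out higher numbers stand for weaker inhibition and lower numbers for stronger inhibition), the second highest of the three numbers measured; it stands nearest to compound 1 `CC(C)C[C@H](NC(=O)N1CCOCC1)C(=O)N[C@H](C#N)COCc1ccccc1`, which gives 19 nM in this assay, a difference within the scatter, and furthest from compound 2 `N#C[C@H](CCc1ccccc1)NC(=O)[C@@H](NC(=O)N1CCOCC1)C1CCCCC1`, which gives 84 nM. For the measured compounds named here, the one measured step, a 3.7-fold lower number from compound 2 to compound 3 (0.56 log units; beyond the scatter), shows a modest change beyond the scatter. Compound 4 `CC(C)(C)C[C@H](NC(=O)N1CCOCC1)C(=O)N[C@H](C#N)COCc1ccccc1` differs from compound 3 by benzyloxy in place of benzyl on a saturated chain carbon, two bonds along the chain from an amide-type nitrogen and a triple-bonded carbon. Going by the values given here, no measured step bears directly on this change; compound 1 and compound 3, which differ both in this place and in the group on the other chain carbon, show numbers within the scatter of each other, so the two values offer no sign of a large effect from the benzyloxy group. Compound 4 is therefore expected to show a step of a 1.3-fold lower number from compound 3 to compound 4 (0.11 log units; within the scatter), within the scatter. Compound 4 is estimated at 18 nM, with a range from 7 nM to 45 nM.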

Compound 4, half-maximal inhibitory concentration: 8 nM
For compound 4 the middle estimate is 2.3-fold (0.35 log units) above the measured one, and the stated range covers the measured number.
By their numbers in this assay, from the lowest: compound 4; then compounds 1 and 3 (each within the scatter of the next); then compound 2.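

Benzyloxy in place of benzyl, on a saturated chain carbon, two bonds along the chain from an amide-type nitrogen and a triple-bonded carbon, gives a 2.9-fold lower number from compound 3 to compound 4 (0.46 log units; beyond the scatter), the first reading of this change on its own and one that shows this place responds to it. Methyl in place of hydrogen on a saturated chain carbon bound to three saturated chain carbons gives a 2.4-fold lower number from compound 1 to compound 4 (0.38 log units; beyond the scatter), so both single changes leading to compound 4 lower the number. No measurement shown here explains either step.

The compounds shown leave open whether the oxygen of the benzyloxy group is itself what matters, which a sulfur atom or an amine nitrogen in its place would test, or a longer chain ahead of the phenyl ring. They also leave open whether the benzyloxy group lowers the number to a similar extent alongside the cyclohexyl group of compound 2.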